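Adding a methoxy group to a pyrazole chalcone: a cytotoxicity estimate

The source may report more compounds than this note shows. Statements on the series, on what has been measured and on what is new or still open speak of the compounds shown alone.

Of the compounds shown here, three have been measured in a functional assay on Hs-578T cells (Homo sapiens) for cytotoxicity, read by sulforhodamine B assay, with a stated time of 48 h, tested at 0.1 uM; a higher number here means a weaker effect of the compound at the concentration tested, a lower number a stronger effect. Compound 1 `COc1ccc(-c2cc(/C=C/C(=O)c3ccc(N)cc3)[nH]n2)cc1` gives 97%, and compound 3 `COc1ccc(-c2cc(/C=C/C(=O)c3ccc(N)cc3)[nH]n2)cc1OC` gives 93%; the step between them, a number 4 percentage points lower from compound 1 to compound 3 (within the scatter), comes from methoxy in place of hydrogen on an aromatic carbon. Compound 2 `COc1ccc(C(=O)/C=C/c2cc(-c3cc(OC)c(OC)c(OC)c3)n[nH]2)cc1OC` gives 99% in this assay ; the difference between the core of compound 2 and the core of compound 1 is not broken down here.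

Compound 4 `COc1cc(C(=O)/C=C/c2cc(-c3cc(OC)c(OC)c(OC)c3)n[nH]2)cc(OC)c1OC` is not yet measured. It arises from compound 2 by methoxy in place of hydrogen on an aromatic carbon. Among the measured compounds shown here, this is the same kind of change as the one from compound 1 to compound 3, though the surroundings are not identical: in compound 4 the new group is also meta to a methoxy group (2 heavy atoms), which was not so in compound 3.

Because a number 4 percentage points lower from compound 1 to compound 3 (within the scatter) stayed within the scatter, the corresponding step is expected to be small as well, estimated at a number 3 percentage points lower from compound 2 to compound 4 (within the scatter) in this assay . Compound 4 is therefore expected to give about 96% in this assay , most likely between 87% and 102%.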

Compound 4, a percentage reported as activity, at one concentration (the size of the read-out at that concentration, not a potency): 90%
Compound 4: middle estimate off by 6 percentage points, on the high side; low and high end bracket the measured number.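

In this assay, methoxy in place of hydrogen on an aromatic carbon gives a number 9 percentage points lower from compound 2 to compound 4 (within the scatter). Set beside the earlier step, the two cores show no measurable difference in how this change behaves: the same change on two cores in this assay, a number 4 percentage points lower (within the scatter) from compound 1 to compound 3 and a number 9 percentage points lower (within the scatter) from compound 2 to compound 4, 5 percentage points apart, within the scatter of two such steps. This shows that the change stayed within the scatter on both cores, but not that it has a real effect of a shared size, since neither step can be told apart from repeated-measurement noise, and two cores tested at a single concentration cannot establish a rule for the series.

The compounds shown leave open whether a different group in the same place, such as a hydroxyl, a chlorine or the longer ethoxy, would give a step beyond the scatter. Among the compounds shown here, they also leave open whether the methoxy step would become clearer at other concentrations, where a single reading near the weak end of the scale would no longer be the only information.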